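Pyrazole carboxylic acids: replacing the biaryl arm with a nitrile

The compounds below may be only part of what the source reports. "The series", "measured", "known", "first", "only" and "open" are said of these compounds alone.

Working notes on a short series of pyrazole acids examined in an assay on isolated protein for inhibition of 2-Hydroxyacid oxidase 2 (Homo sapiens), tested at 10 uM; a lower number here means a weaker effect, a higher number a stronger effect of the compound at the concentration tested. Compound 1 `Cc1n[nH]c(C(=O)O)c1Cc1cccc(-c2ccccc2F)c1` gives 22% in this assay. Compound 2 `Cc1n[nH]c(C(=O)O)c1Cc1ccc(-c2ccc(F)cc2)cc1` gives 25% in this assay. The two numbers sit together, the number for compound 1 being the lower of the two but within the scatter of compound 2, so no order between them can be claimed.

The next step is compound 3 `Cc1n[nH]c(C(=O)O)c1Cc1cccc(C#N)c1`, which has not yet been measured in this assay. The change from compound 1 is cyano in place of 2-fluorophenyl on an aromatic carbon. Among the compounds with values here, no measured pair covers a change of this kind, so no step size is documented. The expectation is for a modest downward move from compound 1 to compound 3, not beyond the scatter, because compound 1 gives only 22% and leaves little room for a large drop; the expected step is a number 7 percentage points lower from compound 1 to compound 3 (within the scatter). Compound 3 is estimated at 15% in this assay, with a range from 2% to 32%.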

Compound 3, a percentage reported as inhibition, at one concentration (the size of the read-out at that concentration, not a potency): 19%
Beside the measured number, compound 3's estimate is 4 percentage points below it; low and high end bracket the measured number.
By their numbers in this assay, from the lowest: compounds 3, 1 and 2 (each within the scatter of the next).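

In this assay, cyano in place of 2-fluorophenyl on an aromatic carbon gives a number 3 percentage points lower from compound 1 to compound 3 (within the scatter). At this position, meta to a large group, the read-out therefore does not separate a cyano group of 2 heavy atoms with no ring from a 2-fluorophenyl group of 7 heavy atoms with a six-membered aromatic ring, so that ring is not required to retain the level of compound 1. No evidence on hand bears on this result.

On these data alone, whether any group on this aromatic carbon can move the number beyond the scatter remains open, for example an amine or a methoxy group. Also open, as far as these compounds go, is whether a longer chain ending in a nitrile would read the same as cyano itself.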